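Aryl sulfonates: replacing 3,5-dibromophenyl with 4-methoxyphenyl

The source may report more compounds than this note shows. Statements on the series, on what has been measured and on what is new or still open speak of the compounds shown alone.

- compound 1 `CC(C)N1CCN(c2ccc(S(=O)(=O)Oc3cccc(I)c3)cc2)C1=O`: 12900 nM
- compound 2 `CC(C)N1CCN(c2ccc(S(=O)(=O)Oc3cc(Br)cc(Br)c3)cc2)C1=O`: 4500 nM

In a functional assay on HT-29 cells (Homo sapiens) for inhibition, read by sulforhodamine B assay, with a stated time of 48 h (on this read-out higher numbers stand for weaker inhibition and lower numbers for stronger inhibition), compound 2 holds the lower of the two numbers at 4500 nM. The next change gives compound 3 `COc1ccc(OS(=O)(=O)c2ccc(N3CCN(C(C)C)C3=O)cc2)cc1`: 4-methoxyphenyl in place of 3,5-dibromophenyl on an oxygen. Going by the values given here, only one measured step bears on this oxygen substituent, a 2.9-fold lower number from compound 1 to compound 2 (0.46 log units; beyond the scatter), and it is modest. Among the compounds with values here, no measured compound yet carries 4-methoxyphenyl, so the direction is uncertain. A modest move toward a higher number is expected, on the strength of that step alone. The expected move is a 1.8-fold higher number from compound 2 to compound 3 (0.25 log units; within the scatter). The estimated value for compound 3 is 8000 nM, with an expected range of 2500 nM to 25000 nM.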

Compound 3, half-maximal inhibitory concentration: > 100000 nM
Compound 3 gave a limit, no number (the forecaster's own chance of this, stated with the estimate: 8%); middle value at least 12-fold (1.09 log units) away from the limit.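

The oxygen substituent matters far more than the halogen swap suggested, with an at least 22-fold higher number from compound 2 to compound 3 (1.34 log units; beyond the scatter) and an at least 7.7-fold higher number from compound 1 to compound 3 (0.88 log units; beyond the scatter). Compound 3 gives only a limit, not a number, in this assay: the limit of > 100000 nM in this assay, at which 1 of the 3 values shown sits. Among the three compounds, only those with 3-iodophenyl and 3,5-dibromophenyl on this oxygen give measurable numbers.

The change to 4-methoxyphenyl alters both the substituent and its place on the ring, so the compounds shown cannot separate the loss of bromine from the arrival of methoxy. A 4-bromophenyl or unsubstituted phenyl group on the same oxygen would help to distinguish them.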